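The source may hold more compounds than are shown below. What is called first, only, known or untested is meant among the compounds shown, and "the series" means these compounds.

The set rests on two measured compounds and one that awaits measurement. Compound 1 `CC(Oc1ccccc1-c1ccccc1)C1=NCCS1` and compound 2 `CC(Oc1ccccc1-c1ccc(O)cc1)C1=NCCN1` share a core and differ in the ring attached to its aromatic carbon and in the cyclic amidine at the other end. In a functional assay on CHO cells for agonist activity at Alpha-2B adrenergic receptor (Homo sapiens) (on this read-out higher numbers stand for larger maximal responses and lower numbers for smaller maximal responses), compound 1 gives < 0.3, which is a limit of the assay and not a number. In this assay compound 2 gives < 0.3, again a limit rather than a number. Both values therefore sit at the limit of < 0.3 in this assay, at which 2 of the 2 values shown sit, and compound 2 cannot be placed above or below compound 1 on the numbers shown; it stands at the floor of what the assay reports.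

Compound 3 `CC(Oc1ccccc1-c1ccncc1)C1=NCCN1` is the next compound, differing from compound 2 by pyridin-4-yl in place of 4-hydroxyphenyl on an aromatic carbon. For the measured compounds named here, no measured step between compounds of this set exists, so the size of the change can only be expected. Compound 3 is expected to show a step that the limit leaves unreadable from compound 2 to compound 3, which is no movement beyond the scatter, since compound 2 already sits at the limit. Compound 3 is expected to reach 0.15, within a range from 0 to 0.4.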

Compound 3, intrinsic activity: the largest response reached, as a fraction of the reference agonist's: < 0.3
Compound 3 was reported as a limit; the forecaster's own chance of this, stated with the estimate: 70%; the middle value is on the limit's open side.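

Compound 3 gives < 0.3 in this assay as a limit and not a number. For the compounds shown here, no step from compound 2 to compound 3 can be read, because both values are limits: the limit of < 0.3 in this assay, at which 3 of the 3 values shown sit. The compounds shown leave open how large a maximal response any of them gives, and whether pyridin-4-yl in place of 4-hydroxyphenyl alters it.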